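Ester-to-acid step on the shared core, Ramos proliferation

The source may report more compounds than this note shows. Statements on the series, on what has been measured and on what is new or still open speak of the compounds shown alone.

Measured so far:
compound 1 `CCOC(=O)c1sc(-c2cccc(NC(=O)c3cccc(F)c3)c2)nc1Nc1ccc(N2CCN(C)CC2)cc1` — 85.2%
compound 2 `CCOC(=O)c1sc(-c2cccc(NC(=O)c3ccc(C#N)cc3)c2)nc1Nc1ccc(N2CCN(C)CC2)cc1` — 97.5%
compound 3 `CCOC(=O)c1sc(-c2cccc(NC(=O)c3ccc(C(F)(F)F)cn3)c2)nc1Nc1ccc(N2CCN(C)CC2)cc1` — 19%

In a functional assay on Ramos cells (Homo sapiens) for antiproliferative activity, read by CCK-8 assay, with a stated time of 72 h, tested at 40 uM (on this read-out lower numbers stand for less inhibition and higher numbers for more inhibition at the one concentration tested (going by the name of the read-out)), compound 1 stands second of the three, with compound 2 a number 12.3 percentage points higher from compound 1 to compound 2 (beyond the scatter) and compound 3 a number 66.2 percentage points lower from compound 1 to compound 3 (beyond the scatter); compound 3 also lies far under compound 2, a number 78.5 percentage points lower from compound 2 to compound 3 (beyond the scatter).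

Compound 4 `CN1CCN(c2ccc(Nc3nc(-c4cccc(NC(=O)c5cccc(F)c5)c4)sc3C(=O)O)cc2)CC1` differs from compound 1 only at the ester: hydrogen in place of ethyl on an oxygen next to a carbonyl group, that is, ethoxycarbonyl becomes carboxy on an oxygen next to a carbonyl group. Among the compounds with values here, every measured step changes the aryl group on the amide carbonyl carbon; none touches the ester, so no measured step bears on this change and no direction can be drawn from the data. The estimate therefore sits near the middle with a wide range, the expected step being a number 40.2 percentage points lower from compound 1 to compound 4 (beyond the scatter). Compound 4 is expected to give about 45%, between 10% and 85%.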

Compound 4, a percentage reported as inhibition, at one concentration (the size of the read-out at that concentration, not a potency): 82.7%
The estimate for compound 4 lay 37.7 percentage points below the measured number; the range from low to high includes it.
By their numbers in this assay, from the lowest: compound 3; then compounds 4 and 1 (each within the scatter of the next); then compound 2.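

In this assay, hydrogen in place of ethyl on an oxygen next to a carbonyl group gives a number 2.5 percentage points lower from compound 1 to compound 4 (within the scatter), the only step shown away from the aryl group on the amide carbonyl. With 3-fluorophenyl held, ethoxycarbonyl and carboxy are therefore not told apart on this read-out at the one concentration tested, whereas a number 66.2 percentage points lower from compound 1 to compound 3 (beyond the scatter) shows the aryl group can move the number far beyond the scatter. No measurement here accounts for this result.

On these data alone, whether carboxy gives the same outcome with the 4-cyanophenyl or 5-(trifluoromethyl)pyridin-2-yl amide stays open. So does the outcome with a primary amide or a longer-chain ester in place of ethoxycarbonyl.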